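This account rests on a few compounds, and the source may have more. Where it says the series, first, only, none or still open, it means among the compounds named here.

The series shares one core, with a carboxymethyl group and a large group on the same five-membered ring. In an in vitro functional assay on HEK285-7 cells for antagonist activity at prostaglandin D2 receptor 2 (Homo sapiens), read by BRET and beta-arrestin recruitment (on this read-out higher numbers stand for weaker inhibition and lower numbers for stronger inhibition), compound 1, `O=C(O)Cc1sc(COc2ccc(Cl)cc2)nc1-c1ccc(Cl)cc1`, gives 370 nM. Compound 2, `CCC(c1ccccc1)c1nc(-c2ccc(Cl)cc2)c(CC(=O)O)s1`, gives only a limit of the assay, > 100000 nM, as noted in the limit of > 100000 nM in this assay, at which 1 of the 3 values shown sits. Compound 3, `O=C(O)Cc1sc(C(c2ccc(F)cc2)c2ccc(F)cc2)nc1-c1ccoc1`, gives 130 nM in this assay, the lowest of the two numbers shown; compound 1 gives a higher number, and that gap is beyond the scatter.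

Compound 4, `CN(C)c1cc(-c2nc(C(c3ccc(F)cc3)c3ccc(F)cc3)sc2CC(=O)O)ccn1`, has not been measured. It differs from compound 3 in one place: 2-(dimethylamino)pyridin-4-yl in place of furan-3-yl on an aromatic carbon. No measured pair shows a change of this kind, so the size of the step from compound 3 to compound 4 in this assay cannot be read from any shown value; a step within the scatter, in either direction, is what is expected, the step being estimated as a 1.5-fold higher number from compound 3 to compound 4 (0.19 log units; within the scatter). Compound 4 is accordingly expected to give about 200 nM in this assay, with a range from 50 nM to 800 nM.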

Compound 4, half-maximal inhibitory concentration: > 100000 nM
Compound 4 was reported as a limit; the forecaster's own chance of this, stated with the estimate: 5%; middle value at least 500-fold (2.69 log units) from the limit.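

At the aromatic carbon next to the ring nitrogen, the group carried matters greatly: with 2-(dimethylamino)pyridin-4-yl in place of furan-3-yl, this assay gives an at least 760-fold higher number from compound 3 to compound 4 (2.88 log units; beyond the scatter). Going by these compounds alone, no two earlier compounds differed in one place, so they could not show the size of any change at this position. The result for compound 4 is a limit of the assay, not a number, so the step has no exact size: the limit of > 100000 nM in this assay, at which 2 of the 4 values shown sit.

The compounds shown do not separate the contribution of the dimethylamino group from that of the pyridine ring, which an unsubstituted pyridin-4-yl or a pyridine bearing a primary amine would address. They also leave open whether the same exchange would have a similar effect with the 4-chlorophenoxymethyl group of compound 1 on the core.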